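A hydroxyethyl added to the carboxamide nitrogen

The compounds below may be only part of what the source reports. "The series", "measured", "known", "first", "only" and "open" are said of these compounds alone.

Measured compounds:
compound 1, `CCN1CCc2c(sc(NC(=O)Nc3ccc(Cl)cc3)c2C(N)=O)C1`: 3120 nM
compound 2, `CCN1CCc2c(sc(NC(=O)Nc3ccc(Cl)cc3Cl)c2C(N)=O)C1`: 11500 nM
compound 3, `CCN1CCc2c(sc(NC(=O)Nc3ccc(Br)cc3)c2C(N)=O)C1`: 3130 nM

All three were tested in a functional assay (strain AB) with Danio rerio as the target, read by microscopy, with a stated time of 1 h; on this read-out lower numbers stand for an effect already at smaller amounts and higher numbers for an effect only at larger amounts of compound. Compound 1 has the lowest number of the three; compound 3 sits nearest, with a 1.0-fold higher number from compound 1 to compound 3 (0.00 log units; within the scatter), and compound 2 furthest, with a 3.7-fold higher number from compound 1 to compound 2 (0.57 log units; beyond the scatter). Within the data shown here, the one step that clears the scatter, a 3.7-fold lower number from compound 2 to compound 3 (0.57 log units; beyond the scatter), concerns the aryl group on the urea.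

Compound 4, `CCN1CCc2c(sc(NC(=O)Nc3ccc(Cl)cc3)c2C(=O)NCCO)C1`, differs from compound 1 at another place: 2-hydroxyethyl in place of hydrogen on an amide-type nitrogen. Among the measured compounds shown here, none of the measured steps touches the amide-type nitrogen that carries this change, so the measured data give no direct guide to its size or direction; they show only that this series tolerates changes at the aryl group within a modest span. On that basis a moderate shift is expected for compound 4, most likely a somewhat higher number, a 1.6-fold higher number from compound 1 to compound 4 (0.20 log units; within the scatter), with wide uncertainty. Compound 4 is therefore estimated at 5000 nM, within a range of 1500 nM to 18000 nM in this assay.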

Compound 4, half-maximal effective concentration: 9400 nM
Beside the measured number, compound 4's estimate is 1.9-fold (0.27 log units) below it, and the stated range covers the measured number.
By their numbers in this assay, from the lowest: compounds 1 and 3 (each within the scatter of the next); then compounds 4 and 2 (each within the scatter of the next).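

In this assay, the amide-type nitrogen turns out to be a place where substitution moves the read-out: 2-hydroxyethyl in place of hydrogen gives a 3.0-fold higher number from compound 1 to compound 4 (0.48 log units; beyond the scatter), and that step is modest in size. The earlier compounds shown here differ only in the aryl group on the urea, so this pair alone speaks to the carboxamide, and here the unsubstituted carbamoyl carries the lower number. Nothing available explains the direction or size of this step.

The compounds shown do not separate the contribution of the terminal hydroxyl from that of the two-carbon chain, which a plain ethyl, a 2-methoxyethyl or a 2-aminoethyl group on the same nitrogen could address. They also leave open how a longer chain such as 3-hydroxypropyl would read, and whether the step recurs with the 4-bromophenyl urea of compound 3.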